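This account rests on a few compounds, and the source may have more. Where it says the series, first, only, none or still open, it means among the compounds named here.

Compound 1 `CCc1ccc(OCCCN2CCC(C(c3ccc(F)cc3)c3ccc(F)cc3)CC2)c(OC)c1` gives 2.51 nM
Compound 2 `Fc1ccc(C(c2ccc(F)cc2)C2CCN(CCCOc3ccc(Cl)cc3)CC2)cc1` gives 2 nM

In a functional assay (aorta) with Oryctolagus cuniculus as the target (a higher number here means weaker binding, a lower number tighter binding), compound 2 gives 2 nM and so stands level with compound 1 at 2.51 nM once the usual scatter is allowed for. The next compound is compound 3 `CC(C)(C)c1ccc(OCCCN2CCC(C(c3ccc(F)cc3)c3ccc(F)cc3)CC2)cc1` with tert-butyl in place of chloro on an aromatic carbon, para to a large group: tert-butyl in place of chloro on an aromatic carbon makes up the whole difference from compound 2.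

For the measured compounds named here, only one measured step bears on this, and only loosely. That step is a 1.3-fold lower number from compound 1 to compound 2 (0.10 log units; within the scatter) and it replaced the whole 4-ethyl-2-methoxyphenyl group with 4-chlorophenyl. Going by the values given here, no measured compound here carries tert-butyl, so a single small step is thin evidence. In this assay the expected step is a 1.3-fold higher number from compound 2 to compound 3 (0.10 log units; within the scatter) and no clear direction is expected beyond the scatter. For compound 3 the estimate is 2.5 nM with an expected range from 0.8 nM to 8 nM in this measurement.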

Compound 3, dissociation constant: 1 nM
Estimate against measurement, compound 3: 2.5-fold (0.40 log units) above, and the stated range covers the measured number.
By their numbers in this assay, from the lowest: compounds 3, 2 and 1 (each within the scatter of the next, the first and the last beyond it).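

In this assay, tert-butyl in place of chloro on the aromatic carbon gives a 2.0-fold lower number from compound 2 to compound 3 (0.30 log units; within the scatter), so at this position a group of 4 heavy atoms stands level with a single chlorine once the usual scatter is allowed for. The wider swap of the whole 4-ethyl-2-methoxyphenyl group for 4-(tert-butyl)phenyl gives a 2.5-fold lower number from compound 1 to compound 3 (0.40 log units; beyond the scatter), a modest step that lies beyond the scatter, but it changes more than one place on the ring and cannot be assigned to any one of them. Nothing measured here gives a reason for either step.

As far as these compounds go, whether an amine, a hydroxyl or a carboxylic acid on this same aromatic carbon would stay level with chloro and tert-butyl remains open. So does the contribution of the methoxy group of compound 1 on its own, as no pair shown changes it alone.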